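The source may report more compounds than this note shows. Statements on the series, on what has been measured and on what is new or still open speak of the compounds shown alone.

Compound 1 `CN1CCN(c2ccc(Nc3ncc4nc([S+]([O-])c5ccccc5)n([C@H]5CC[C@H](O)CC5)c4n3)cc2)CC1` gives 268 nM in a functional assay on HCC827 cells (Homo sapiens) for antiproliferative activity, read by MTT assay, with a stated time of 72 h; a lower number here means a stronger inhibitor, a higher number a weaker inhibitor. Compound 2 `CN1CCN(c2ccc(Nc3ncc4nc([S+]([O-])c5ccccc5)n(CC5CC5)c4n3)cc2)CC1` gives 838 nM in this assay, and the change cyclopropylmethyl in place of 4-hydroxycyclohexyl on an aromatic nitrogen made the step of a 3.1-fold higher number from compound 1 to compound 2 (0.50 log units; beyond the scatter). Compound 3 `CN1CCN(c2ccc(Nc3ncc4nc(Sc5ccccc5)n([C@H]5CC[C@H](O)CC5)c4n3)cc2)CC1` gives 42.6 nM in this assay; its core differs from that of compound 1 by a group of 7 heavy atoms (6 carbon, 1 sulfur; one six-membered aromatic ring of carbon only) in place of a group of 8 heavy atoms (6 carbon, 1 oxygen, 1 sulfur; one six-membered aromatic ring of carbon only), on an aromatic carbon, which made the step of a 6.3-fold lower number from compound 1 to compound 3 (0.80 log units; beyond the scatter). Compound 4 `CN1CCN(c2ccc(Nc3ncc4nc(Sc5ccccc5)n(CC5CC5)c4n3)cc2)CC1` is not yet measured. It differs from compound 3 by cyclopropylmethyl in place of 4-hydroxycyclohexyl on an aromatic nitrogen, the same kind of change as before, though here the ring atom beside the altered nitrogen bears a phenylsulfanyl group (7 heavy atoms) rather than a group of 8 heavy atoms. Going by the values given here, compound 4 is expected to show a step of a 3.1-fold higher number from compound 3 to compound 4 (0.48 log units; beyond the scatter) in this assay, resting on the single earlier step of a 3.1-fold higher number from compound 1 to compound 2 (0.50 log units; beyond the scatter). Compound 4 is therefore estimated at 130 nM, between 55 nM and 320 nM.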

Compound 4, half-maximal inhibitory concentration: 660 nM
The estimate for compound 4 lay 5.1-fold (0.71 log units) below the measured number, and the stated range ends below it.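

In this assay, cyclopropylmethyl in place of 4-hydroxycyclohexyl gave a 15-fold higher number from compound 3 to compound 4 (1.19 log units; beyond the scatter), so the size of this step did not carry over from the core of compound 1: the same change on two cores in this assay, a 3.1-fold higher number (0.50 log units; beyond the scatter) from compound 1 to compound 2 and a 15-fold higher number (1.19 log units; beyond the scatter) from compound 3 to compound 4, 5.0-fold (0.70 log units) apart, beyond the scatter of two such steps

Read the other way, phenylsulfanyl in place of the group of 8 heavy atoms gave a 1.3-fold lower number from compound 2 to compound 4 (0.10 log units; within the scatter), so that change counted only with 4-hydroxycyclohexyl on the nitrogen: the same change on two cores in this assay, a 6.3-fold lower number (0.80 log units; beyond the scatter) from compound 1 to compound 3 and a 1.3-fold lower number (0.10 log units; within the scatter) from compound 2 to compound 4, 5.0-fold (0.70 log units) apart, beyond the scatter of two such steps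

These four compounds show that the two changes do not act independently, although the cyclopropylmethyl change raised the number on both cores, but they do not show why or whether this holds for other groups.

A plain cyclohexyl group, or a short chain ending in a hydroxyl, would help separate the role of the ring from that of the hydroxyl. The compounds shown leave open which of these goes with the larger step.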